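Half-life in acid: ring size of the carbonate group

A few compounds are considered here, and "the series" means these few. Any claim that something is new, unique, unknown or untested is made for them only; others in the source may bear on it.

Among the measured compounds shown here, compound 3 `C[C@@H](O)[C@H]1C(=O)N2C(C(=O)OCOC(=O)O[C@H]3CCCCc4ccccc43)=C(S[C@@H]3CN[C@H](C(=O)N(C)C)C3)[C@H](C)[C@H]12` gives 0.155 h in a physicochemical assay for metabolic stability, read by HPLC, in simulated gastric fluid, at pH 1.2, tested at 100 uM (on this read-out higher numbers stand for a longer-lived compound and lower numbers for a shorter-lived compound), the lowest of the three numbers so far. Compound 2 `CC(OC(=O)O[C@H]1CCCCc2ccccc21)OC(=O)C1=C(S[C@@H]2CN[C@H](C(=O)N(C)C)C2)[C@H](C)[C@@H]2[C@@H]([C@@H](C)O)C(=O)N12` gives 0.3 h in this assay, and the gap a 1.9-fold lower number from compound 2 to compound 3 (0.29 log units; within the scatter) sits within the scatter, so no order between compounds 2 and 3 can be claimed. Compound 1 `C[C@@H](O)[C@H]1C(=O)N2C(C(=O)OCOC(=O)OC3CCCc4ccccc4C3)=C(S[C@@H]3CN[C@H](C(=O)N(C)C)C3)[C@H](C)[C@H]12` gives 0.35 h, and the step of a 2.3-fold lower number from compound 1 to compound 3 (0.35 log units; beyond the scatter) shows that a swap between two groups of the same size on the oxygen next to the carbonyl group does shift the read-out.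

Compound 4 `C[C@@H](O)[C@H]1C(=O)N2C(C(=O)OCOC(=O)OC3CCc4ccccc4C3)=C(S[C@@H]3CN[C@H](C(=O)N(C)C)C3)[C@H](C)[C@H]12` differs from compound 3 only there: a group of 10 heavy atoms (10 carbon; one six-membered non-aromatic ring of carbon only, one six-membered aromatic ring of carbon only) in place of a group of 11 heavy atoms (11 carbon; one six-membered aromatic ring of carbon only, one seven-membered non-aromatic ring of carbon only), on an oxygen next to a carbonyl group. For the measured compounds named here, the only step bearing on this position is a 2.3-fold lower number from compound 1 to compound 3 (0.35 log units; beyond the scatter), which concerns an exchange of groups of equal size, so it indicates the position is sensitive but gives no direction for a smaller ring. Going by the values given here, no other measured step informs this change. The expected step of a 1.3-fold higher number from compound 3 to compound 4 (0.11 log units; within the scatter) is therefore small and without a firm direction, likely within the scatter. Compound 4 is estimated at 0.2 h, with a range from 0.1 h to 0.45 h.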

Compound 4, half-life: 0.233 h
Beside the measured number, compound 4's estimate is 1.2-fold (0.07 log units) below it; the measured number falls inside the stated range.
By their numbers in this assay, from the lowest: compounds 3, 4, 2 and 1 (each within the scatter of the next, the first and the last beyond it).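

In this assay, placing 1,2,3,4-tetrahydronaphthalen-2-yl on an oxygen next to a carbonyl group gives two steps within the scatter: a 1.5-fold higher number from compound 3 to compound 4 (0.18 log units; within the scatter) and a 1.5-fold lower number from compound 1 to compound 4 (0.18 log units; within the scatter). Compound 4 therefore cannot be ordered against either compound 1 or compound 3, even though those two stand apart beyond the scatter, so this swap to 1,2,3,4-tetrahydronaphthalen-2-yl shows no readable difference in half-life from either. No supporting data are available to explain the read-out at this position.

On these data alone, whether an open alkyl chain or a ring bearing an amine on this oxygen would shift the half-life beyond the scatter remains open. Also open, as far as these compounds go, is how the methyl on the saturated chain carbon bound to two oxygens would read alongside 1,2,3,4-tetrahydronaphthalen-2-yl.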